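Acyl variation on the piperidine amide series: compound 4

The source may report more compounds than this note shows. Statements on the series, on what has been measured and on what is new or still open speak of the compounds shown alone.

Measured so far, for displacement of a labelled ligand:
compound 1 `CC[C@@H](NC(=O)CC(C)C)C(=O)N1CCC(c2ccc(Cl)cc2)CC1` gives 152 nM
compound 2 `CC(C)CC(=O)N[C@@H](C(=O)N1CCC(c2ccc(Cl)cc2)CC1)C(C)C` gives 32 nM
compound 3 `CC[C@@H](C)[C@@H](NC(=O)CC(C)C)C(=O)N1CCC(c2ccc(Cl)cc2)CC1` gives 34 nM

In an assay on THP-1 cells for displacement of a labelled ligand from C-C chemokine receptor type 1 (Homo sapiens) (on this read-out lower numbers stand for stronger inhibition and higher numbers for weaker inhibition), compound 2 has the lowest of the three numbers. Its nearest neighbour is compound 3, whose value lies within the scatter of it, so no order between compound 2 and compound 3 is claimed. The step of a 4.8-fold lower number from compound 1 to compound 2 (0.68 log units; beyond the scatter) and the step of a 4.5-fold lower number from compound 1 to compound 3 (0.65 log units; beyond the scatter) are both beyond the scatter; the step of a 1.1-fold higher number from compound 2 to compound 3 (0.03 log units; within the scatter) is not.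

Compound 4 `CC(C)[C@@H](NC(=O)c1ccc(F)c(F)c1)C(=O)N1CCC(c2ccc(Cl)cc2)CC1` differs from compound 2 at the acyl side: 3,4-difluorophenyl in place of isobutyl on a carbonyl carbon. All three measured steps concern the saturated chain carbon next to the amide nitrogen, not the carbonyl substituent, so none of them bears on this change. There is no measured basis for a direction. The expected outcome for compound 4 in this assay is therefore a step of a 1.3-fold higher number from compound 2 to compound 4 (0.10 log units; within the scatter) of undetermined direction, with a wide spread.

The estimate for compound 4 in this assay is 40 nM, expected between 6 nM and 250 nM.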

Compound 4, half-maximal inhibitory concentration: 14 nM
Beside the measured number, compound 4's estimate is 2.9-fold (0.46 log units) above it, within the range that was stated.
By their numbers in this assay, from the lowest: compound 4; then compounds 2 and 3 (each within the scatter of the next); then compound 1.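

In this assay, among these compounds, 3,4-difluorophenyl in place of isobutyl on a carbonyl carbon gives a 2.3-fold lower number from compound 2 to compound 4 (0.36 log units; beyond the scatter), the only measured step on the acyl side of the series; the earlier steps all concerned the saturated chain carbon. This place therefore accepts a six-membered aromatic ring in place of a branched saturated chain with no loss, and the number moves modestly downward, beyond the scatter. No measurement at hand accounts for this step.

Going by these compounds, whether the step belongs to the aromatic ring itself or to its two fluorines stays open; a plain phenyl or a pyridine on the same carbonyl carbon would separate the two. Also open, on these data alone, is whether the same exchange gives a step of similar size and direction on the side chains of compound 1 and compound 3.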